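The compounds below may be only part of what the source reports. "The series", "measured", "known", "first", "only" and "open" are said of these compounds alone.

Of the compounds shown here, three built on one shared core have been measured in a physicochemical assay for solubility, at pH 1.2; a lower number here means a less soluble compound, a higher number a more soluble compound. Compound 2 `CC(C)n1ncn(-c2ccc(N3CCN(c4ccc(OC[C@H]5CO[C@](Cn6cncn6)(c6ccc(F)cc6F)O5)cc4)CC3)nc2)c1=O` gives 1680 ug/mL, the highest of the three numbers. Compound 3 `CC(C)n1ncn(-c2ccc(N3CCN(c4ccc(OC[C@H]5CO[C@](Cn6cncn6)(c6ccc(F)cc6F)O5)cc4)CC3)cn2)c1=O` gives 320 ug/mL, and compound 1 `CC(C)(CO)Cn1ncn(-c2ccc(N3CCN(c4ccc(OC[C@H]5CO[C@](Cn6cncn6)(c6ccc(F)cc6F)O5)cc4)CC3)cn2)c1=O` gives 190 ug/mL; both of these lie beyond the scatter below compound 2. Among the measured compounds shown here, the only measured step that alters a single place is a 1.7-fold higher number from compound 1 to compound 3 (0.23 log units; within the scatter), a change made on the same aromatic nitrogen that is the subject here. Compound 4 `CC(C)Cn1ncn(-c2ccc(N3CCN(c4ccc(OC[C@H]5CO[C@](Cn6cncn6)(c6ccc(F)cc6F)O5)cc4)CC3)nc2)c1=O` differs from compound 2 only at that place: isobutyl in place of isopropyl on an aromatic nitrogen. The measured step from compound 1 to compound 3 stayed within the scatter, so the change in compound 4 gives little ground to expect a large movement; a small shift downward, or none beyond the scatter, seems the most likely outcome. The step is therefore expected to be a 1.9-fold lower number from compound 2 to compound 4 (0.27 log units; within the scatter). Compound 4 is estimated to give 900 ug/mL, within a range of 350 ug/mL to 2000 ug/mL.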

Compound 4, solubility: 2330 ug/mL
The estimate for compound 4 lay 2.6-fold (0.41 log units) below the measured number; the whole stated range lies below it.
By their numbers in this assay, from the lowest: compounds 1 and 3 (each within the scatter of the next); then compounds 2 and 4 (each within the scatter of the next).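

In this assay, the step to isobutyl on this aromatic nitrogen gives a 1.4-fold higher number from compound 2 to compound 4 (0.14 log units; within the scatter), so compound 2 and compound 4 cannot be told apart. Together with a 1.7-fold higher number from compound 1 to compound 3 (0.23 log units; within the scatter), it gives a second change at this place that stays within the scatter, now on the core of compound 2 rather than that of compound 1. Nothing shown here accounts for why the number stayed where it did.

All the groups shown at this place are alkyl chains, one of them bearing a hydroxymethyl branch, so they do not show how far this position can move the number in this assay. From the compounds shown here alone, it remains open whether an amine, a carboxylic acid or a longer chain on this nitrogen would give a step beyond the scatter.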